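Trifluoromethyl Moved Around the Ring: Effect on Liver-Cell Toxicity

The source may report more compounds than this note shows. Statements on the series, on what has been measured and on what is new or still open speak of the compounds shown alone.

Compound 1 `COc1ccc(-c2cc(Cl)cn3c([N+](=O)[O-])c(CS(=O)(=O)c4ccccc4)nc23)cc1` was tested in an ADME assay on HepG2 cells (Homo sapiens) for cytotoxicity, read by MTT assay, with a stated time of 72 h; on this read-out higher numbers stand for lower toxicity in this test and lower numbers for higher toxicity in this test. In this assay compound 1 gives only a limit, > 3900 nM. Compound 2 `CCN(CC)c1ccc(-c2cc(Cl)cn3c([N+](=O)[O-])c(CS(=O)(=O)c4ccccc4)nc23)cc1` likewise gives only a limit in this assay, > 15600 nM. Compound 3 `O=[N+]([O-])c1c(CS(=O)(=O)c2ccccc2)nc2c(-c3cccc(C(F)(F)F)c3)cc(Cl)cn12` also gives only a limit in this assay, > 12500 nM. All three values are limits, so the steps a step that the two limits leave unreadable from compound 1 to compound 2, a step that the two limits leave unreadable from compound 1 to compound 3 and a step that the two limits leave unreadable from compound 2 to compound 3 remain unreadable. Compound 4 `O=[N+]([O-])c1c(CS(=O)(=O)c2ccccc2)nc2c(-c3ccccc3C(F)(F)F)cc(Cl)cn12` has not been measured; it differs from compound 1 by 2-(trifluoromethyl)phenyl in place of 4-methoxyphenyl on an aromatic carbon. The step from compound 1 to compound 3 is the nearest comparison, yet its size cannot be read, so no change beyond the scatter is expected in this assay. Compound 4 is therefore estimated at 15000 nM, within 5000 nM to 50000 nM, probably again as a limit. The expected step is a step that the limit leaves unreadable from compound 1 to compound 4.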

Compound 4, half-maximal cytotoxic concentration: 22700 nM
For compound 4 the middle estimate is 1.5-fold (0.18 log units) below the measured one; the range from low to high includes it.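

Compounds 1, 2 and 3 give only limits in this assay, and none of their steps to compound 4 can be read. From the compounds shown here alone, whether 2-(trifluoromethyl)phenyl and 3-(trifluoromethyl)phenyl differ in this assay stays open.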